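Acyl heteroaryl swap on the shared chromone amide core

The compounds below may be only part of what the source reports. "The series", "measured", "known", "first", "only" and "open" are said of these compounds alone.

In an assay on isolated protein for inhibition of Rho-associated protein kinase 2 (Homo sapiens), read by scintillation counting, radiometric assay and 33P incorporation, with a stated time of 40 min, in the presence of a further agent that is not named here (on this read-out higher numbers stand for weaker inhibition and lower numbers for stronger inhibition), compound 2 `CC(C)(C)c1cc(C(=O)Nc2cccc(NC(=O)COc3ccc4c(=O)ccoc4c3)c2)no1` gives 5 nM, the lowest of the two numbers measured; compound 1 `O=C(COc1ccc2c(=O)ccoc2c1)Nc1cccc(NC(=O)c2ccc(F)cc2)c1` gives 54 nM. The step of an 11-fold lower number from compound 1 to compound 2 (1.03 log units; beyond the scatter) shows that the group on this carbonyl carbon moves this assay strongly. Compound 3 `Cc1nc(C(=O)Nc2cccc(NC(=O)COc3ccc4c(=O)ccoc4c3)c2)cs1` carries the change (2-methyl-1,3-thiazol-4-yl in place of 5-(tert-butyl)-1,2-oxazol-3-yl on a carbonyl carbon). Within the data shown here, only that one step bears on it, and it was measured with 5-(tert-butyl)-1,2-oxazol-3-yl entering, not leaving; a higher number in this assay is therefore expected for compound 3, with the step of a 4.0-fold higher number from compound 2 to compound 3 (0.60 log units; beyond the scatter) as the expected size. Compound 3 is estimated at 20 nM, within 5 nM to 80 nM.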

Compound 3, half-maximal inhibitory concentration: 33 nM
Compound 3: middle estimate off by 1.7-fold (0.22 log units), on the low side; the measured number falls inside the stated range.
By their numbers in this assay, from the lowest: compound 2; then compounds 3 and 1 (each within the scatter of the next).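

On a carbonyl carbon whose other neighbour is an amide-type nitrogen, a second five-membered aromatic ring with two hetero atoms does not match 5-(tert-butyl)-1,2-oxazol-3-yl in this assay, with a 6.6-fold higher number from compound 2 to compound 3 (0.82 log units; beyond the scatter) for this change. A five-membered aromatic ring alone is thus not enough for the low number of compound 2, and a 1.6-fold lower number from compound 1 to compound 3 (0.21 log units; within the scatter) leaves 2-methyl-1,3-thiazol-4-yl and 4-fluorophenyl unseparated. Nothing measured here accounts for these differences. Open, from the compounds shown here alone, is whether the tert-butyl group or the ring carries the effect; 5-methyl-1,2-oxazol-3-yl or 2-(tert-butyl)-1,3-thiazol-4-yl on this carbonyl carbon would separate the two.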